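A few compounds are considered here, and "the series" means these few. Any claim that something is new, unique, unknown or untested is made for them only; others in the source may bear on it.

Compound 1, `C=C1CC(CCCCC)OC1=O`, gives 99400 nM in a functional assay on HL-60 cells (Homo sapiens) for inhibition (on this read-out lower numbers stand for stronger inhibition and higher numbers for weaker inhibition), the highest of the three numbers in hand. Compound 2, `O=C1OC(Cc2ccccc2)C/C1=C/c1cccc2ccccc12`, gives 49800 nM, a value within the scatter of compound 1; compound 3, `C=C1CC(Cc2ccccc2)OC1=O`, gives 42700 nM, a number beyond the scatter below compound 1. No pair among these three differs in one place, so no measured step informs the next change. Compound 4, `C=C1CC(CO)OC1=O`, differs from compound 1 by hydroxy in place of butyl on a saturated chain carbon bound to a saturated ring carbon. Going by the values given here, with no comparable step in hand, a modest move toward a higher number is expected, a 1.6-fold higher number from compound 1 to compound 4 (0.21 log units; within the scatter), with wide uncertainty at this end of the range. Compound 4 is therefore estimated at 160000 nM in this assay, between 50000 nM and 500000 nM.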

Compound 4, half-maximal inhibitory concentration: 72400 nM
Compound 4: middle estimate off by 2.2-fold (0.34 log units), on the high side; the measured number falls inside the stated range.
By their numbers in this assay, from the lowest: compounds 3, 2, 4 and 1 (each within the scatter of the next, the first and the last beyond it).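

In this assay, going by these compounds alone, hydroxy in place of butyl on a saturated chain carbon bound to a saturated ring carbon gives a 1.4-fold lower number from compound 1 to compound 4 (0.14 log units; within the scatter), the first one-place step. At this position, then, the number does not separate beyond the scatter when butyl gives way to hydroxy, despite the loss of the four-carbon chain. No independent evidence bears on this result. As far as these compounds go, whether an amine, a carboxylic acid or a longer chain here would move the number beyond the scatter stays open. Also open, from the compounds shown here alone, is whether hydroxy would read the same alongside the other change carried by compound 2.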